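A few compounds are considered here, and "the series" means these few. Any claim that something is new, unique, unknown or untested is made for them only; others in the source may bear on it.

Measured so far:
- compound 1 `CC(C)=CCC[C@]1(C)/C=C/[C@@H](OC(=O)C=C(C)C)[C@](C)(O)/C=C/C(=O)/C(C(=O)O)=C\C1`: > 10000 nM
- compound 2 `CC(C)=CCC[C@]1(C)/C=C/[C@@H](OC(=O)C=C(C)C)[C@](C)(O)/C=C/C(=O)/C(Cn2cc(CO)nn2)=C\C1`: 3560 nM

Going by the values given here, in a functional assay on SMMC-7721 cells (Homo sapiens) for antiproliferative activity, read by MTT assay, with a stated time of 48 h (a higher number here means a weaker inhibitor, a lower number a stronger inhibitor), compound 2 gives 3560 nM, the only true number available so far. Compound 1 gives > 10000 nM, which is a limit of the assay and not a number.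

The next compound is compound 3 `CCN(CC)C(=O)/C1=C/C[C@](C)(CCC=C(C)C)/C=C/[C@@H](OC(=O)C=C(C)C)[C@](C)(O)/C=C/C1=O`, which has diethylcarbamoyl in place of (4-(hydroxymethyl)-1H-1,2,3-triazol-1-yl)methyl on a double-bonded ring carbon. Among the compounds with values here, only one measured step bears on this place: an at least 2.8-fold lower number from compound 1 to compound 2 (0.44 log units; beyond the scatter). That step swapped carboxy for the triazole-bearing group and gave a lower number, so the group here can matter. As far as these compounds go, its full size is unknown, since it starts from a limit. Compound 3 lacks the carboxy of compound 1 and shares no other feature of that group, so the expectation stays close to compound 2 at 3560 nM, perhaps slightly weaker. No step beyond the scatter is therefore expected in this assay, and the expected step is a 1.4-fold higher number from compound 2 to compound 3 (0.15 log units; within the scatter). For compound 3 the estimated value is 5000 nM, with an expected range of 1800 nM to 14000 nM.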

Compound 3, half-maximal inhibitory concentration: 13800 nM
Estimate against measurement, compound 3: 2.8-fold (0.44 log units) below, and the stated range covers the measured number.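

In this assay, going by these compounds alone, the change from the triazole-bearing group to diethylcarbamoyl on the double-bonded ring carbon gives a 3.9-fold higher number from compound 2 to compound 3 (0.59 log units; beyond the scatter), the first step at this place that runs between two true numbers and so has a readable size. The two groups are close in heavy-atom count, with 8 leaving and 7 entering, yet the values still differ beyond the scatter, so in this pair that count alone does not set the value. Compound 1 gives > 10000 nM, which is a limit and not a number, and the step from it to compound 3 therefore cannot be read: the limit of > 10000 nM in this assay, at which 1 of the 3 values shown sits.

The step from compound 2 to compound 3 changes several things at once, as the ring, the hydroxy group and the number of hydrogen-bond acceptors all differ, so these two compounds cannot show which of those features goes with the change in value. A triazole-bearing group with plain methyl in place of hydroxymethyl would test the hydroxy group alone, while a piperidine amide would test a ring within the amide series.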